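A few compounds are considered here, and "the series" means these few. Any claim that something is new, unique, unknown or untested is made for them only; others in the source may bear on it.

Compound 3 `Cc1nc(-c2nc(N)c3cc(Cc4ccccc4)sc3n2)cs1` gives 263 nM in a functional assay on CHO-K1 cells for antagonist activity at adenosine receptor A1 (Homo sapiens), read by a beta-galactosidase reporter and cAMP accumulation, with stated times of 15 min and 6 h (a lower number here means a stronger inhibitor, a higher number a weaker inhibitor), and stands second highest of the three numbers: close to compound 1 `CCc1ccc(-c2nc(N)c3cc(Cc4ccccc4)sc3n2)o1` at 223 nM, and well apart from compound 2 `Cc1csc(-c2nc(N)c3cc(Cc4ccccc4)sc3n2)n1` at 1490 nM. Compound 4 `COc1cccc(-c2nc(N)c3cc(Cc4ccccc4)sc3n2)c1` arises from compound 3 by 3-methoxyphenyl in place of 2-methyl-1,3-thiazol-4-yl on an aromatic carbon. Within the data shown here, no measured step exchanges a five-membered heteroaryl for a phenyl, so only the size of earlier aryl swaps can guide: a 1.2-fold higher number from compound 1 to compound 3 (0.07 log units; within the scatter), a 5.7-fold lower number from compound 2 to compound 3 (0.75 log units; beyond the scatter) and a 6.7-fold higher number from compound 1 to compound 2 (0.82 log units; beyond the scatter). Those swaps ranged from no change to a modest one in either direction, so for compound 4 a step of uncertain direction and at most modest size in this assay is expected. The estimate for compound 4 is 320 nM, with a range from 80 nM to 1300 nM, meaning a 1.2-fold higher number from compound 3 to compound 4 (0.09 log units; within the scatter).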

Compound 4, inhibition constant: 266 nM
Estimate against measurement, compound 4: 1.2-fold (0.08 log units) above; measured number inside the range.
By their numbers in this assay, from the lowest: compounds 1, 3 and 4 (each within the scatter of the next); then compound 2.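

At the carbon between two ring nitrogen atoms, the series is not confined to five-membered heteroaryl groups: with 3-methoxyphenyl, this assay gives a 1.0-fold higher number from compound 3 to compound 4 (0.00 log units; within the scatter) and a 1.2-fold higher number from compound 1 to compound 4 (0.08 log units; within the scatter). Among these compounds, the same group also gives a 5.6-fold lower number from compound 2 to compound 4 (0.75 log units; beyond the scatter), which leaves 4-methyl-1,3-thiazol-2-yl as the only one of the four groups set apart. Nothing available accounts for this pattern.

As far as these compounds go, whether the methoxy group itself contributes remains open, as does the effect of moving it around the phenyl ring. A morpholine or a carboxylic acid on the phenyl ring is also untested by these compounds.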